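This account rests on a few compounds, and the source may have more. Where it says the series, first, only, none or still open, it means among the compounds named here.

Working notes on the urea series. Two compounds have numbers in a functional assay on NCI-H460 cells (Homo sapiens) for cytotoxicity, read by MTT assay, with a stated time of 72 h; a higher number here means a weaker inhibitor, a lower number a stronger inhibitor. Compound 1 `O=C(Nc1ccc(-n2ncc3c(C(F)(F)F)cccc32)cc1)Nc1ccc(Cl)c(C(F)(F)F)c1` gives 1600 nM in this assay. Going by the values given here, compound 2 `O=C(Nc1ccc(-n2ncc3c(F)cccc32)cc1)Nc1ccc(Cl)c(C(F)(F)F)c1` gives 3400 nM in this assay and stands highest of the two numbers; the one measured step, a 2.1-fold higher number from compound 1 to compound 2 (0.33 log units; beyond the scatter), separates it from compound 1. Compound 3 `O=C(Nc1ccc(-n2ncc3ccncc32)cc1)Nc1ccc(Cl)c(C(F)(F)F)c1` is not yet measured. From compound 2 to compound 3 the change is a group of 9 heavy atoms (6 carbon, 3 nitrogen; one five-membered aromatic ring with 2 hetero atoms, one six-membered aromatic ring with 1 hetero atom) in place of a group of 10 heavy atoms (7 carbon, 2 nitrogen, 1 fluorine; one five-membered aromatic ring with 2 hetero atoms, one six-membered aromatic ring of carbon only), on an aromatic carbon: a group of 9 heavy atoms (6 carbon, 3 nitrogen; one five-membered aromatic ring with 2 hetero atoms, one six-membered aromatic ring with 1 hetero atom) in place of a group of 10 heavy atoms (7 carbon, 2 nitrogen, 1 fluorine; one five-membered aromatic ring with 2 hetero atoms, one six-membered aromatic ring of carbon only), on an aromatic carbon. Among the compounds with values here, no measured step bears directly on it: the step from compound 1 to compound 2 exchanged one substituent on the bicyclic group for another, whereas here the bicyclic group itself is replaced. Without a comparable step, no shift beyond the scatter is expected for compound 3 in this assay, with the uncertainty left wide. The expected step from compound 2 is no change at the digits printed from compound 2 to compound 3 (within the scatter). Compound 3 is estimated at 3400 nM, between 1200 nM and 9500 nM.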

Compound 3, half-maximal inhibitory concentration: 4800 nM
Beside the measured number, compound 3's estimate is 1.4-fold (0.15 log units) below it, within the range that was stated.
By their numbers in this assay, from the lowest: compound 1; then compounds 2 and 3 (each within the scatter of the next).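

Replacing the 4-fluoro-1H-indazol-1-yl group with the entering group, whose six-membered aromatic ring holds 1 hetero atom, gives a 1.4-fold higher number from compound 2 to compound 3 (0.15 log units; within the scatter) in this assay, so at this place, on an aromatic carbon para to a large group, the bicyclic group itself can be altered without a shift beyond the scatter. The earlier step showed only an exchange of one substituent on the bicyclic group; this step removes the fluoro substituent, alters the ring atoms and goes from 2 to 3 hydrogen-bond acceptors, all at once, and the number stays within the scatter. Going by these compounds alone, no measurement at hand accounts for this result, and the single step cannot divide its outcome among those differences.

The compounds shown leave open what the loss of fluoro and the ring nitrogen each contribute alone, which a bicyclic group with no fluoro and with carbon only in its six-membered ring would separate. They also leave open whether an amine or a carboxylic acid on the bicyclic group would stay within the scatter of these numbers or move beyond it.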